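This account rests on a few compounds, and the source may have more. Where it says the series, first, only, none or still open, it means among the compounds named here.

Measured so far:
Compound 1 `Cn1c(-c2ccc(NC(=O)CSc3nc4cc(Cl)ccc4o3)cc2)nc(-c2ccccc2)c1-c1ccccc1`: 11.9%
Compound 2 `Cc1nnc(SCC(=O)Nc2ccc(-c3nc(-c4ccccc4)c(-c4ccccc4)n3C)cc2)s1`: 34.8%
Compound 3 `CCN1CCN(CC(=O)Nc2ccc(-c3nc(-c4ccccc4)c(-c4ccccc4)n3C)cc2)CC1`: 7.4%

In a functional assay on HT-29 cells (Homo sapiens) for cytotoxicity, read by MTT assay, with a stated time of 24 h, tested at 0.64 ug/mL (a lower number here means a weaker effect, a higher number a stronger effect of the compound at the concentration tested), compound 1 stands second highest of the three numbers. Compound 3 lies nearest to it, since the step of a number 4.5 percentage points lower from compound 1 to compound 3 (within the scatter); compound 2 lies furthest, since a number 22.9 percentage points higher from compound 1 to compound 2 (beyond the scatter).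

Compound 4 `CN(C)/C=C/N1CCN(CC(=O)Nc2ccc(-c3nc(-c4ccccc4)c(-c4ccccc4)n3C)cc2)CC1` has not yet been tested. Relative to compound 1 it shows (4-(2-(dimethylamino)ethenyl)piperazin-1-yl in place of (5-chloro-1,3-benzoxazol-2-yl)sulfanyl on a saturated chain carbon bound to a carbonyl carbon). Among the compounds with values here, the one measured step that resembles this change is the one to compound 3, where a piperazin-1-yl group also replaced the sulfanyl group in the same place, and a number 4.5 percentage points lower from compound 1 to compound 3 (within the scatter). Within the data shown here, no measured step tells what the 2-(dimethylamino)ethenyl group adds. The expectation is therefore a step no larger than the scatter, a number 2.9 percentage points lower from compound 1 to compound 4 (within the scatter), giving an estimated 9% for compound 4, within a range of 2% to 20%.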

Compound 4, a percentage reported as activity, at one concentration (the size of the read-out at that concentration, not a potency): 3.1%
Compound 4: middle estimate off by 5.9 percentage points, on the high side; the measured number falls inside the stated range.
By their numbers in this assay, from the lowest: compounds 4, 3 and 1 (each within the scatter of the next); then compound 2.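

In this assay, 2-(dimethylamino)ethenyl in place of ethyl on an amine nitrogen in a ring gives a number 4.3 percentage points lower from compound 3 to compound 4 (within the scatter) and so cannot be told apart from the ethyl group. The change from the chlorobenzoxazolyl sulfanyl group gives a number 8.8 percentage points lower from compound 1 to compound 4 (within the scatter) and the change from the thiadiazolyl sulfanyl group gives a number 31.7 percentage points lower from compound 2 to compound 4 (beyond the scatter), which sets compound 2 clear of compound 4, as it was of compound 3. No evidence here explains these numbers.

Open, on these data alone, is whether a morpholin-4-yl group at this place would read differently, and whether the number of compound 2 belongs to its 5-methyl group or to its ring.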